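Shrinking the Ring on a Thiocarbonyl Carbon

The compounds below may be only part of what the source reports. "The series", "measured", "known", "first", "only" and "open" are said of these compounds alone.

Of the compounds shown here, two have been tested in a functional assay on HeLa cells (Homo sapiens) for antiproliferative activity, read by CCK-8 assay, with a stated time of 72 h, tested at 8 uM; a higher number here means a stronger effect of the compound at the concentration tested, a lower number a weaker effect. Compound 1, `Nc1ccccc1NC(=O)c1ccc(CSC(=S)N2CCc3ccccc32)cc1`, gives 67% in this assay. Compound 2, `N#Cc1ccc(N2CCN(C(=S)SCc3ccc(C(=O)Nc4ccccc4N)cc3)CC2)cc1`, gives 70.6% in this assay. Compound 1 thus holds the lower of the two numbers, but the two values lie within the usual scatter of each other, so nothing separates them. Compound 3, `Nc1ccccc1NC(=O)c1ccc(CSC(=S)N2CCCC2)cc1`, has not yet been measured. It differs from compound 1 in one place: pyrrolidin-1-yl in place of 2,3-dihydro-1H-indol-1-yl on a thiocarbonyl carbon. The six-membered aromatic ring of carbon only is lost, leaving a smaller five-membered non-aromatic ring with 1 hetero atom on the thiocarbonyl carbon whose other neighbour is sulfur. For the measured compounds named here, no measured pair shows what such a change does here, so the expectation rests on the structural difference alone. A modest loss, probably just beyond the scatter, is expected. Compound 3 is estimated at 55%, within a range of 35% to 72%. That corresponds to an expected step of a number 12 percentage points lower from compound 1 to compound 3 (beyond the scatter).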

Compound 3, a percentage reported as inhibition, at one concentration (the size of the read-out at that concentration, not a potency): 77.8%
Compound 3: the middle estimate sits 22.8 percentage points below what was measured, and the stated range ends below it.
By their numbers in this assay, from the lowest: compounds 1, 2 and 3 (each within the scatter of the next, the first and the last beyond it).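

In this assay, for the compounds shown here, the first readable step on this thiocarbonyl carbon is a gain: pyrrolidin-1-yl in place of 2,3-dihydro-1H-indol-1-yl gives a number 10.8 percentage points higher from compound 1 to compound 3 (beyond the scatter) and so lies just beyond the scatter. For this pair, then, losing the six-membered aromatic ring of carbon only costs nothing at the concentration tested, and the group with fewer heavy atoms reads higher. No measurement shown here explains why the smaller ring gives the higher number.

On these data alone, it remains open whether this gain carries over to a six-membered non-aromatic ring such as piperidin-1-yl, or to an open-chain amine such as diethylamino, on the same thiocarbonyl carbon. A reading at one concentration gives the size of an effect and not a potency, so the potency of compound 3 relative to compound 1 also stays unsettled.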